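This account rests on a few compounds, and the source may have more. Where it says the series, first, only, none or still open, it means among the compounds named here.

Measured so far:
Compound 1, `Cn1c(-c2ccc(NC(=O)CCl)cc2)nc(-c2ccccc2)c1-c1ccccc1`: in a functional assay on MCF7 cells (Homo sapiens) for cytotoxicity, read by MTT assay, with a stated time of 24 h, tested at 1.6 ug/mL (on this read-out higher numbers stand for a stronger effect at the one concentration tested and lower numbers for a weaker effect), compound 1 gives 4.3%.
Compound 2, `Cn1c(-c2ccc(NC(=O)CSC3=NCCS3)cc2)nc(-c2ccccc2)c1-c1ccccc1`: in this assay compound 2 gives 16.2%.
Compound 3, `Cn1ccnc1SCC(=O)Nc1ccc(-c2nc(-c3ccccc3)c(-c3ccccc3)n2C)cc1`: in this assay compound 3 gives 17.5%.

Compound 3 has the highest of the three numbers, but its margin over compound 2 is within the scatter, so those two cannot be ranked against each other; only compound 1 sits clearly lower, as seen in a number 13.2 percentage points higher from compound 1 to compound 3 (beyond the scatter) and in a number 11.9 percentage points higher from compound 1 to compound 2 (beyond the scatter). Compound 4, `CCN1CCN(CC(=O)Nc2ccc(-c3nc(-c4ccccc4)c(-c4ccccc4)n3C)cc2)CC1`, has not yet been measured. It differs from compound 3 at one place: 4-ethylpiperazin-1-yl in place of (1-methyl-1H-imidazol-2-yl)sulfanyl on a saturated chain carbon bound to a carbonyl carbon. Within the data shown here, none of the measured steps swaps a group of this kind, so there is no direct precedent. The closest guide is a number 1.3 percentage points higher from compound 2 to compound 3 (within the scatter), where one five-membered ring replaced another on the sulfur and the number did not move. The two steps away from compound 1 show that replacing chloro at this position with a larger group raised the number modestly, but compound 4 keeps a larger group there, so a shift of that size is not implied in either direction. Compound 4 is therefore expected to stay near compound 3, with a number 3.5 percentage points lower from compound 3 to compound 4 (within the scatter) estimated to fall within the scatter. The estimate for compound 4 is 14%, ranging from 3% to 28%.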

Compound 4, a percentage reported as activity, at one concentration (the size of the read-out at that concentration, not a potency): 14.6%
Estimate against measurement, compound 4: 0.6 percentage points below, within the range that was stated.
By their numbers in this assay, from the lowest: compound 1; then compounds 4, 2 and 3 (each within the scatter of the next).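

In this assay, the sulfur atom is not required on the saturated chain carbon bound to a carbonyl carbon: 4-ethylpiperazin-1-yl has no sulfur and brings a six-membered non-aromatic ring in place of a five-membered aromatic one, yet the change gives a number 2.9 percentage points lower from compound 3 to compound 4 (within the scatter) and, against the other sulfur-linked compound, a number 1.6 percentage points lower from compound 2 to compound 4 (within the scatter). Replacing chloro with this sulfur-free group also gives a number 10.3 percentage points higher from compound 1 to compound 4 (beyond the scatter), so among the compounds shown, compound 1 alone stands apart, while three quite different replacements for chloro cannot be told apart from one another. No supporting measurement is available to explain why these three groups read alike or why chloro reads differently.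

The compounds shown leave open whether a ring is needed at all at this position, since a small open-chain amine such as dimethylamino or a carboxylic acid could read like the three ring-bearing groups or like chloro. As far as these compounds go, it is also open whether a longer chain carrying the same 4-ethylpiperazin-1-yl group would keep the number where it is or move it.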